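A few compounds are considered here, and "the series" means these few. Any claim that something is new, unique, unknown or untested is made for them only; others in the source may bear on it.

Measured compounds:
compound 1 `COc1ccc(/C=C/C(=O)c2ccc(OC)c(OC)c2)cc1`: 78.9%
compound 2 `COc1ccc(/C=C/C(=O)c2ccc(OC)c(OC)c2)cc1OC`: 81.3%

Both numbers come from an ADME assay on RAW264.7 cells (Mus musculus) for cytotoxicity, read by MTT assay, with a stated time of 24 h, tested at 5 ug/mL; on this read-out higher numbers stand for a weaker effect at the one concentration tested and lower numbers for a stronger effect. Compound 2 stands at the higher of the two values, but its separation from compound 1, the step of a number 2.4 percentage points higher from compound 1 to compound 2 (within the scatter), lies within the scatter, so the two compounds cannot be told apart on this read-out. Compound 3 `COc1ccc(/C=C/C(=O)c2ccc(OC)c(OC)c2)cc1O` has not yet been measured. It differs from compound 2 by hydrogen in place of methyl on an oxygen on an aromatic ring. For the measured compounds named here, the only step available for comparison is the one from compound 1 to compound 2, where a methoxy entered in place of hydrogen on an aromatic carbon and the read-out moved by a number 2.4 percentage points higher from compound 1 to compound 2 (within the scatter). Going by the values given here, no measured step removes a methyl from an oxygen on an aromatic ring, so nothing in the data speaks directly to the change toward compound 3. Among the compounds with values here, with the one known step lying within the scatter, no movement beyond the scatter is expected in this assay. Compound 3 is therefore estimated at 78%, with a range from 62% to 92%, an expected step of a number 3.3 percentage points lower from compound 2 to compound 3 (within the scatter).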

Compound 3, a percentage reported as activity, at one concentration (the size of the read-out at that concentration, not a potency): 73%
For compound 3 the middle estimate is 5 percentage points above the measured one; the range from low to high includes it.
By their numbers in this assay, from the lowest: compounds 3, 1 and 2 (each within the scatter of the next).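

In this assay, the first change made on an oxygen on an aromatic ring, methoxy to hydroxy, gives a number 8.3 percentage points lower from compound 2 to compound 3 (within the scatter), so removing the methyl does not separate the two compounds on this read-out, even though this step brings in a hydroxy rather than adding another methoxy. Set against the compound with hydrogen on that aromatic carbon, the hydroxy gives a number 5.9 percentage points lower from compound 1 to compound 3 (within the scatter), so hydrogen, methoxy and hydroxy at this place, taken in every pair, all stay within the scatter of one another, which the single earlier step could show only for hydrogen and methoxy. Nothing available accounts for the size or direction of these small steps, and no measurement bears on why they arise.

What the compounds shown leave open is whether an amine, a carboxylic acid or a longer chain on that oxygen, such as ethoxy or propoxy, would also stay within the scatter in this assay. They also leave open whether the three compounds would remain indistinguishable at any concentration other than the single one tested here.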